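Trading Three Chlorines for a Single Bromine

The source may report more compounds than this note shows. Statements on the series, on what has been measured and on what is new or still open speak of the compounds shown alone.

Three compounds built on one shared core have so far been run in a functional assay on HCT-116 cells (Homo sapiens) for antiproliferative activity, read by MTT assay, with a stated time of 72 h; on this read-out higher numbers stand for weaker inhibition and lower numbers for stronger inhibition. Compound 3 `NC1=NC2(CCSCC2)N(OCCCOc2cc(Cl)c(Cl)cc2Cl)C(N)=N1` gives 1 nM, the lowest number of the three. Compound 1 `NC1=NC2(CCSCC2)N(OCCCOc2ccc(Cl)cc2)C(N)=N1` gives 10 nM, and compound 2 `COc1ccc(OCCCON2C(N)=NC(N)=NC23CCSCC3)cc1` gives 70 nM. The steps of a 10-fold lower number from compound 1 to compound 3 (1.00 log units; beyond the scatter) and a 70-fold lower number from compound 2 to compound 3 (1.85 log units; beyond the scatter) both run down toward the ring carrying three chlorines, while the step of a 7.0-fold higher number from compound 1 to compound 2 (0.85 log units; beyond the scatter) shows methoxy in place of chloro pushing the number up.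

Compound 4 `NC1=NC2(CCSCC2)N(OCCCOc2cccc(Br)c2)C(N)=N1` has not yet been measured. It differs from compound 3 as follows: 3-bromophenyl in place of 2,4,5-trichlorophenyl on an oxygen on a saturated carbon. The steps into compound 3 bear most on this change: because the steps of a 10-fold lower number from compound 1 to compound 3 (1.00 log units; beyond the scatter) and a 70-fold lower number from compound 2 to compound 3 (1.85 log units; beyond the scatter) both gave a lower number on moving to the 2,4,5-trichlorophenyl ring, moving away from that ring to a 3-bromophenyl ring is expected to give a higher number in this assay, somewhere near compound 1. The expected step is a 15-fold higher number from compound 3 to compound 4 (1.18 log units; beyond the scatter). Compound 4 is estimated at 15 nM, with a range from 4 nM to 60 nM.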

Compound 4, half-maximal inhibitory concentration: 1 nM
Beside the measured number, compound 4's estimate is 15-fold (1.18 log units) above it; the whole stated range lies above it.
By their numbers in this assay, from the lowest: compounds 3 and 4 (each within the scatter of the next); then compound 1; then compound 2.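

The ring on an oxygen on a saturated carbon does not need three chlorines to reach the lowest numbers in this series: the step shows no change at the digits printed from compound 3 to compound 4 (within the scatter), so one bromine in the 3-bromophenyl ring matches the 2,4,5-trichlorophenyl ring within the usual scatter. The same ring gives a 10-fold lower number from compound 1 to compound 4 (1.00 log units; beyond the scatter) and a 70-fold lower number from compound 2 to compound 4 (1.85 log units; beyond the scatter), so carrying a single ring substituent does not by itself hold the number up, even though compound 1 and compound 2 also carry only one. Nothing measured here explains why these two rings give matching numbers.

Going by these compounds, what a 3-chlorophenyl or a 4-bromophenyl ring would give stays open, and with it whether the halogen or its place on the ring sets the number. So does the outcome with an amine or a carboxylic acid on this ring, or with a longer chain leading to it.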